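A few compounds are considered here, and "the series" means these few. Any claim that something is new, unique, unknown or untested is made for them only; others in the source may bear on it.

Compound 2, `Cc1nc(N)sc1CCCN/C(N)=N/C(=O)NC(C)c1ccc(F)cc1`, is one of two closely related compounds tested in an assay on membranes from Sf9 cells for displacement of a labelled ligand from histamine H2 receptor (Homo sapiens), read by scintillation counting, with a stated time of 60 min; a lower number here means a stronger inhibitor, a higher number a weaker inhibitor. In this assay, within the data shown here, compound 2 gives 31.6 nM, the lower of the two numbers measured so far, while compound 1, `Cc1nc(N)sc1CCCN/C(N)=N/C(=O)NC(C)c1ccc(Cl)cc1`, gives 46.8 nM. Among the measured compounds shown here, the single measured step, a 1.5-fold lower number from compound 1 to compound 2 (0.17 log units; within the scatter), lies within the scatter, so the two cannot really be told apart.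

Compound 3, `Cc1nc(N)sc1CCCN/C(N)=N/C(=O)NC(C)c1cccs1`, differs from compound 2 in one place: thiophen-2-yl in place of 4-fluorophenyl on a saturated chain carbon bound to an amide-type nitrogen and a saturated chain carbon. This is the same ring that changed between compound 1 and compound 2, where swapping one halogen for another made no difference beyond the scatter. For the measured compounds named here, no measured step covers exchanging the ring itself, so the expectation rests on that one small step.

Because a 1.5-fold lower number from compound 1 to compound 2 (0.17 log units; within the scatter) lies within the scatter, compound 3 is expected to stay close to compound 2. The estimated step of a 1.3-fold higher number from compound 2 to compound 3 (0.10 log units; within the scatter) is therefore expected to be no larger than the scatter. Compound 3 is estimated at 40 nM, with a range from 15 nM to 120 nM.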

Compound 3, inhibition constant: 63.1 nM
Estimate against measurement, compound 3: 1.6-fold (0.20 log units) below; the measured number falls inside the stated range.
By their numbers in this assay, from the lowest: compounds 2, 1 and 3 (each within the scatter of the next).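

In this assay, the earlier pair changed only the halogen on the ring, whereas here the whole ring is exchanged on the saturated chain carbon, and the steps of a 2.0-fold higher number from compound 2 to compound 3 (0.30 log units; within the scatter) and a 1.3-fold higher number from compound 1 to compound 3 (0.13 log units; within the scatter) both lie within the scatter. At this place, thiophen-2-yl can therefore stand in for 4-fluorophenyl or 4-chlorophenyl with no difference these numbers can resolve, even though it has fewer heavy atoms and brings sulfur and a hydrogen-bond acceptor. Nothing available explains why the exchange leaves the number within the scatter.

On these data alone, all three compounds carry an aromatic ring at this place, so it remains open whether any such ring is needed. A saturated ring such as cyclohexyl, a plain alkyl chain or a ring bearing an amine could give a very different number.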